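The compounds below may be only part of what the source reports. "The series", "measured", "known", "first", "only" and "open" are said of these compounds alone.

Measured compounds:
Compound 1, `N#Cc1cc(=O)[nH]c(=O)n1[C@@H]1O[C@H](CO)[C@@H](O)[C@H]1O`: in a functional assay on OCI-Ly7 cells (Homo sapiens) for antiproliferative activity, read by WST assay, with a stated time of 3 days (on this read-out lower numbers stand for stronger inhibition and higher numbers for weaker inhibition), compound 1 reaches only a limit, > 50000 nM.
Compound 2, `O=c1cc(I)n([C@@H]2O[C@H](CO)[C@@H](O)[C@H]2O)c(=O)[nH]1`: in this assay compound 2 reaches only a limit, > 50000 nM.
Compound 3, `Nc1cc(=O)[nH]c(=O)n1[C@@H]1O[C@H](CO)[C@@H](O)[C@H]1O`: in this assay compound 3 reaches only a limit, > 50000 nM.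

Compound 2 thus stands where the other two stand, at the limit of this assay; no number separates any of them, as the limit of > 50000 nM in this assay, at which 3 of the 3 values shown sit, records. The steps measured so far are a step that the two limits leave unreadable from compound 1 to compound 2, a step that the two limits leave unreadable from compound 1 to compound 3 and a step that the two limits leave unreadable from compound 2 to compound 3; none can be read for size, as both ends of each sit at the limit.

Compound 4, `COC(=O)c1cc(=O)[nH]c(=O)n1[C@@H]1O[C@H](CO)[C@@H](O)[C@H]1O`, differs from compound 2 by methoxycarbonyl in place of iodo on an aromatic carbon. Within the data shown here, no measured step bears on this exchange with a readable size; the three exchanges already made at this aromatic carbon all left the limit in place, and the methoxycarbonyl is a fourth group there. The expected step from compound 2 to compound 4 in this assay is therefore a step that the limit leaves unreadable from compound 2 to compound 4, with a further limit the most likely outcome. Compound 4 is estimated at 60000 nM, with a range from 20000 nM to 200000 nM.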

Compound 4, half-maximal inhibitory concentration: > 50000 nM
Compound 4: no number, only a limit; the forecaster's own chance of this, stated with the estimate: 85%; the middle value lies beyond the limit too.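

Among these compounds, no step involving compound 4 can be read, nor any step among compound 1, compound 2 and compound 3; all sit at the same limit: the limit of > 50000 nM in this assay, at which 4 of the 4 values shown sit.

The compounds shown leave open whether any group at this aromatic carbon gives a readable value in this assay.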